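Swapping the Aryl Group: Expectation for Compound 4

The source may hold more compounds than are shown below. What is called first, only, known or untested is meant among the compounds shown, and "the series" means these compounds.

Of the compounds shown here, three that share a common core have been measured in an assay on isolated protein for inhibition of Amine oxidase [flavin-containing] B (Homo sapiens), read by spectrophotometry; a higher number here means a weaker inhibitor, a lower number a stronger inhibitor. Compound 1 `COc1ccccc1/C=N/Nc1nc2ccccc2nc1Cc1ccccc1` gives 790000 nM, the highest of the three numbers. Compound 3 `C(=N/Nc1nc2ccccc2nc1Cc1ccccc1)\c1ccccc1` gives 320000 nM, and compound 2 `COc1cc(/C(C)=N/Nc2nc3ccccc3nc2Cc2ccccc2)cc(OC)c1OC` gives 260000 nM; compound 1 therefore stands nearest to compound 3 and furthest from compound 2, and both gaps lie beyond the scatter. Among the measured compounds shown here, the only single-point step among the measured compounds is a 2.5-fold lower number from compound 1 to compound 3 (0.39 log units; beyond the scatter).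

Compound 4 `CN(C)c1ccc(/C=N/Nc2nc3ccccc3nc2Cc2ccccc2)cc1` is the next candidate. It differs from compound 1 by 4-(dimethylamino)phenyl in place of 2-methoxyphenyl on a carbon with a double bond to nitrogen. For the measured compounds named here, no measured pair changes the aryl group in just this way, so the step from compound 1 to compound 3 is the only guide: taking away the methoxy group from compound 1 gave a modest lowering, and exchanging the whole 2-methoxyphenyl group for 4-(dimethylamino)phenyl is expected to give a lowering of comparable size, although, with no closer precedent, the direction is not secure. The expected step is a 2.8-fold lower number from compound 1 to compound 4 (0.45 log units; beyond the scatter). Compound 4 is therefore estimated at 280000 nM, within a range from 90000 nM to 850000 nM.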

Compound 4, half-maximal inhibitory concentration: 880000 nM
Estimate against measurement, compound 4: 3.1-fold (0.50 log units) below; measured number above the stated range.
By their numbers in this assay, from the lowest: compounds 2 and 3 (each within the scatter of the next); then compounds 1 and 4 (each within the scatter of the next).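

In this assay, the exchange of 2-methoxyphenyl for 4-(dimethylamino)phenyl on a carbon with a double bond to nitrogen gives a 1.1-fold higher number from compound 1 to compound 4 (0.05 log units; within the scatter), so this assay does not tell these two aryl groups apart. Measured against the plain phenyl group, dimethylamino in place of hydrogen on an aromatic carbon gives a 2.8-fold higher number from compound 3 to compound 4 (0.44 log units; beyond the scatter), so compound 3 now stands apart from both compound 1 and compound 4, and among these three the ring without a substituent carries the lower number, although compound 2, with methoxy groups on its aryl ring, goes against any wider pattern by standing within the scatter of compound 3. Nothing in the data shown accounts for why the two substituted aryl groups read alike.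

Left open is whether the place of a group on the aromatic ring matters apart from the group itself. Also open, going by these compounds, is whether a different group at this position, such as a carboxylic acid, a hydroxyl or a fluorine, would give a number clearly apart from those seen so far.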